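A chlorophenyl ethenyl group replaces a methyl

The compounds below may be only part of what the source reports. "The series", "measured", "known", "first", "only" and "open" are said of these compounds alone.

Measured so far in an ADME assay on NIH3T3 cells (Mus musculus) for cytotoxicity, read by MTT assay, with a stated time of 48 h; a lower number here means that less compound is tolerated, a higher number that more compound is tolerated:
Compound 1 `COc1ccc(C(C)=O)cc1S(=O)(=O)Nc1c(N)nc(SC)[nH]c1=O` gives > 1600000 nM (a limit, not a number)
Compound 2 `COc1ccc(/C=C/C(=O)c2ccc(OC)c(S(N)(=O)=O)c2)cc1` gives 96000 nM
Compound 3 `COc1ccc(C(=O)/C=C/c2cc(OC)c(OC)c(OC)c2)cc1S(N)(=O)=O` gives 2400 nM

Compound 1 stands at the limit of > 1600000 nM in this assay, at which 1 of the 3 values shown sits, and no number is known for it. Compound 4 `COc1ccc(C(=O)/C=C/c2ccc(Cl)cc2)cc1S(=O)(=O)Nc1c(N)nc(SC)[nH]c1=O` has not yet been measured. It carries 2-(4-chlorophenyl)ethenyl in place of methyl on a carbonyl carbon. In this assay a large fall is expected, meaning less compound tolerated, and the estimated change is an at least 80-fold lower number from compound 1 to compound 4 (1.90 log units; beyond the scatter) in size. Compound 2 at 96000 nM and compound 3 at 2400 nM also carry a substituted ethenyl on a carbonyl carbon, and this expectation rests on them, though both differ from compound 4 elsewhere. Compound 4 is estimated at 20000 nM (expected range 2500 nM to 150000 nM).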

Compound 4, concentration lethal to 50% of the cells: 13000 nM
Beside the measured number, compound 4's estimate is 1.5-fold (0.19 log units) above it; the range from low to high includes it.
By their numbers in this assay, from the lowest: compound 3; then compound 4; then compound 2. At a limit, above all of these: compound 1.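

Swapping methyl for 2-(4-chlorophenyl)ethenyl on a carbonyl carbon gives an at least 120-fold lower number from compound 1 to compound 4 (2.09 log units; beyond the scatter) in this assay. This is the only one-place comparison shown, and it ties the drop in tolerated concentration directly to this position on the core of compound 1. The step has no exact size, because compound 1 carries only a limit and not a number: the limit of > 1600000 nM in this assay, at which 1 of the 4 values shown sits.

Still open, going by these compounds, is whether the step comes from the ethenyl link or from the chlorine on its ring. On these data alone, how an amine or a longer alkyl chain on this carbonyl carbon would behave also remains open.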